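Adding an ethoxy group to the benzyl ring of compound 1

The compounds below may be only part of what the source reports. "The series", "measured", "known", "first", "only" and "open" are said of these compounds alone.

Compound 1 `COc1cccc(OC)c1OCCNCCOc1ccccc1OCc1ccccc1` is the strongest of the three measured compounds in a functional assay on thoracic aorta for antagonist activity at Alpha-1D adrenergic receptor (Rattus norvegicus) (a higher number here means a more potent compound, by a factor of ten per unit of this negative logarithm, a lower number a less potent compound), giving 9.37. Compound 2 `COc1cccc(OC)c1OCCNCCOc1ccccc1OCc1ccc(C)cc1` gives 9.12 in this assay, and compound 3 `COc1cccc(OC)c1OCCNCCOc1ccccc1OCc1ccccc1[N+](=O)[O-]` gives 8.95. The step from compound 1 to compound 4 `CCOc1ccc(COc2ccccc2OCCNCCOc2c(OC)cccc2OC)cc1` is ethoxy in place of hydrogen on an aromatic carbon, placed para to a large group. The closest comparison is a number 0.25 log units lower from compound 1 to compound 2 (within the scatter), a small group added on the same ring. The other change, a number 0.42 log units lower from compound 1 to compound 3 (beyond the scatter), brought a modest loss. A small loss, or none beyond the scatter, is therefore expected here, and the expected step is a number 0.32 log units lower from compound 1 to compound 4 (beyond the scatter). Compound 4 is estimated to give 9.05 in this assay, within a range from 8.6 to 9.5.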

Compound 4, negative logarithm of the antagonist equilibrium constant: 9.11
Compound 4: middle estimate off by 0.06 log units, on the low side, within the range that was stated.
By their numbers in this assay, from the lowest: compounds 3, 4, 2 and 1 (each within the scatter of the next, the first and the last beyond it).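

In this assay, ethoxy on this aromatic carbon, para to a large group, leaves the number within the scatter of the unsubstituted benzyl compound (a number 0.26 log units lower from compound 1 to compound 4 (within the scatter)). Ethoxy in place of methyl makes no readable difference (a number 0.01 log units lower from compound 2 to compound 4 (within the scatter)), and neither does 4-ethoxyphenyl in place of 2-nitrophenyl (a number 0.16 log units higher from compound 3 to compound 4 (within the scatter)), so at this position a group of three heavy atoms is tolerated as well as methyl. No supporting data bear on the reason for this. As far as these compounds go, whether an amine, a carboxylic acid or a longer chain such as butoxy would be tolerated here remains open.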